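Aryl group on the ring nitrogen: step to compound 4

The source may report more compounds than this note shows. Statements on the series, on what has been measured and on what is new or still open speak of the compounds shown alone.

Compound 1 `Cc1ccccc1-n1nc(-c2ccccc2)nc1CNc1ccc(C(=O)NO)cc1`: 57.1%
Compound 2 `Cc1cccc(-n2nc(-c3ccccc3)nc2CNc2ccc(C(=O)NO)cc2)c1`: 66%
Compound 3 `O=C(NO)c1ccc(NCc2nc(-c3ccccc3)nn2-c2ccc(Cl)cc2)cc1`: 55.4%

Three compounds share one core and differ only in the aryl group on an aromatic nitrogen; all were read in an assay on Sf9 cells for inhibition of protein deacetylase HDAC6 (Homo sapiens), read by fluorescence, with a stated time of 40 min, tested at 100 nM; a lower number here means less inhibition, a higher number more inhibition at the concentration tested (going by the name of the read-out). Compound 3 stands lowest of the three numbers: compound 1 lies nearest, within the scatter, and compound 2 lies furthest, beyond it.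

Compound 4 `Cc1cc(C)cc(-n2nc(-c3ccccc3)nc2CNc2ccc(C(=O)NO)cc2)c1` is not yet measured. Relative to compound 3 the change is 3,5-dimethylphenyl in place of 4-chlorophenyl on an aromatic nitrogen.

Going by the values given here, two measured steps bear on this. The step of a number 10.6 percentage points lower from compound 2 to compound 3 (beyond the scatter) goes from a 3-methylphenyl group to the 4-chlorophenyl group of compound 3, and compound 4 carries methyl groups again, now two of them, so the reverse of that step is the closest guide. The step of a number 1.7 percentage points lower from compound 1 to compound 3 (within the scatter) shows a second methylphenyl sitting close to compound 3. A rise back toward the level of compound 2 is therefore expected, modest in size: the expected step is a number 9.6 percentage points higher from compound 3 to compound 4 (within the scatter). Compound 4 is estimated at 65%, with a range from 52% to 78%.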

Compound 4, a percentage reported as inhibition, at one concentration (the size of the read-out at that concentration, not a potency): 49.8%
For compound 4 the middle estimate is 15.2 percentage points above the measured one; measured number below the stated range.
By their numbers in this assay, from the lowest: compounds 4, 3, 1 and 2 (each within the scatter of the next, the first and the last beyond it).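

Adding one more methyl to the aryl group on the aromatic nitrogen, with 3,5-dimethylphenyl in place of the 3-methylphenyl group, gives a number 16.2 percentage points lower from compound 2 to compound 4 (beyond the scatter) in this assay and is the largest step yet seen at this position, so the level of compound 2 does not simply follow from the presence of methyl groups. The other two steps, a number 5.6 percentage points lower from compound 3 to compound 4 (within the scatter) and a number 7.3 percentage points lower from compound 1 to compound 4 (within the scatter), place compound 4 with compound 3 and compound 1, which leaves compound 2 as the only aryl variant with any step beyond the scatter. No measurement at hand accounts for the drop from compound 2.

The compounds shown leave open how a methoxy or a dimethylamino group on this phenyl ring would read, or a saturated cyclohexyl ring in its place. They also leave open whether a single methyl on the 3-position differs from a single chlorine there, since the chlorine shown is the 4-chlorophenyl group.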